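Compound 3 to compound 4: exchanging the sulfanyl group

This account rests on a few compounds, and the source may have more. Where it says the series, first, only, none or still open, it means among the compounds named here.

Measured in an ADME assay on HEK293 cells (Homo sapiens) for cytotoxicity; a higher number here means a weaker inhibitor, a lower number a stronger inhibitor:
- compound 1 `COC(=O)c1c(C)cc(OC(=O)c2c(C)cc(O)c(/C=N/NC(=O)CNc3ccc(C)cc3)c2O)c(C)c1O`: > 100000 nM (a limit)
- compound 2 `COC(=O)c1c(C)cc(OC(=O)c2c(C)cc(O)c(/C=N/NC(=O)COc3cccc(C)c3)c2O)c(C)c1O`: > 100000 nM (a limit)
- compound 3 `COC(=O)c1c(C)cc(OC(=O)c2c(C)cc(O)c(/C=N/NC(=O)CSc3nc4ccccc4s3)c2O)c(C)c1O`: 70100 nM

Among the compounds with values here, compound 3 holds the only actual number in the set. Compound 1 and compound 2 both sit at the limit of > 100000 nM in this assay, at which 2 of the 3 values shown sit. Compound 4 `COC(=O)c1c(C)cc(OC(=O)c2c(C)cc(O)c(/C=N/NC(=O)COc3cc(C)ccc3C(C)C)c2O)c(C)c1O` is the next case, and the change is 2-isopropyl-5-methylphenoxy in place of (1,3-benzothiazol-2-yl)sulfanyl on a saturated chain carbon bound to a carbonyl carbon.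

The nearest measured change is an at least 1.4-fold lower number from compound 2 to compound 3 (0.15 log units; that floor lies within the scatter). The other, an at least 1.4-fold lower number from compound 1 to compound 3 (0.15 log units; that floor lies within the scatter), has the same size, and a step that the two limits leave unreadable from compound 1 to compound 2 gives nothing to read. As far as these compounds go, both readable steps are only floors within the scatter, so the true sizes remain open. The expectation rests on compound 2, which also carries a phenoxy group and gives > 100000 nM, a limit. A small move to a higher number is therefore expected, a 1.2-fold higher number from compound 3 to compound 4 (0.08 log units; within the scatter), hardly beyond the scatter. Compound 4 is estimated at 85000 nM, with an expected range of 35000 nM to 160000 nM.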

Compound 4, half-maximal inhibitory concentration: > 100000 nM
Compound 4 gave a limit, no number; the forecaster's own chance of this, stated with the estimate: 50%; middle value at least 1.1-fold (0.07 log units) away from the limit.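

In this assay, a second substituted phenoxy group on the saturated chain carbon bound to a carbonyl carbon again gives no number, and compound 4 ends at the limit of the assay, as compound 2 does: the limit of > 100000 nM in this assay, at which 3 of the 4 values shown sit.

Putting 2-isopropyl-5-methylphenoxy in place of (1,3-benzothiazol-2-yl)sulfanyl gives an at least 1.4-fold higher number from compound 3 to compound 4 (0.15 log units; that floor lies within the scatter), so this exchange shows no difference beyond the scatter. The steps among compound 1, compound 2 and compound 4 cannot be read: all three values are limits.

As far as these compounds go, how far these three compounds lie past the limit remains open, and with it whether any of them truly differs from compound 3. Also open, from the compounds shown here alone, is whether an amine such as piperidine or a carboxylic acid on the same saturated chain carbon would give a number within the range of the assay.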